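This account rests on a few compounds, and the source may have more. Where it says the series, first, only, none or still open, it means among the compounds named here.

Measured so far:
Compound 1, `C[C@H](Nc1ncnc2[nH]cnc12)c1cc2ccc(F)cn2c(=O)c1-c1ccccc1`: 94%
Compound 2, `C[C@H](Nc1nc(N)nc(N)c1C#N)c1cc2ccc(F)cn2c(=O)c1-c1ccccc1`: 42%
Compound 3, `Cc1nc(N)nc(N[C@@H](C)c2cc3ccc(F)cn3c(=O)c2-c2ccccc2)c1C#N`: 8%

These numbers come from an ADME assay on microsomes from liver (Mus musculus), read by LC-MS, using NADPH, with a stated time of 30 min, tested at 1 uM; a higher number here means that more of the compound is left, a lower number that less of the compound is left. Compound 3 stands lowest of the three: a number 34 percentage points lower from compound 2 to compound 3 (beyond the scatter) and a number 86 percentage points lower from compound 1 to compound 3 (beyond the scatter), both beyond the scatter. Compound 4, `Cc1nc(N)nc(N[C@@H](C)c2c(-c3ccccc3)c(=O)n3cc(F)ccc3c2C)c1C#N`, differs from compound 3 by one small change: methyl in place of hydrogen on an aromatic carbon. Among the compounds with values here, none of the measured steps touches this part of the molecule; all three alter the group on the amine nitrogen, and the closest in kind, a number 34 percentage points lower from compound 2 to compound 3 (beyond the scatter), is a methyl in place of an amino group on an aromatic carbon of a different part of the molecule. So no measured step anchors an expectation, and with compound 3 already near the bottom of the scale there is little room for a further drop; the expected step is a number 2 percentage points higher from compound 3 to compound 4 (within the scatter), nothing beyond the scatter. Compound 4 is therefore expected to give about 10% in this assay, between 2% and 30%.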

Compound 4, percent of the compound remaining: 75%
Compound 4: middle estimate off by 65 percentage points, on the low side; measured number outside the range, above it.
By their numbers in this assay, from the lowest: compound 3; then compound 2; then compound 4; then compound 1.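

In this assay, methyl in place of hydrogen on this aromatic carbon gives a number 67 percentage points higher from compound 3 to compound 4 (beyond the scatter). Within the data shown here, the earlier steps all changed the group on the amine nitrogen, so this is the first sign that a single added carbon on the shared core can also shift the percent remaining by a large amount. Nothing measured here explains the rise. On these data alone, whether an ethyl or a methoxy group on this carbon would give a similar step remains open, as does whether methyl here would do the same in compound 1 or compound 2.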